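Methyl Added to a Series Near the Assay Ceiling

This account rests on a few compounds, and the source may have more. Where it says the series, first, only, none or still open, it means among the compounds named here.

Measured so far:
compound 1 `N#CC1=C(N)Oc2c(c3nc4ccccc4nc3c3ccccc23)C12C(=O)N(Cc1cnnn1-c1cccc(Cl)c1)c1ccccc12`: 32600 nM
compound 2 `Cc1cc(C)cc(-n2nncc2CN2C(=O)C3(C(C#N)=C(N)Oc4c3c3nc5ccccc5nc3c3ccccc43)c3ccccc32)c1`: > 50000 nM (a limit of the assay)
compound 3 `Cc1ccc(-n2nncc2CN2C(=O)C3(C(C#N)=C(N)Oc4c3c3nc5ccccc5nc3c3ccccc43)c3ccccc32)cc1Cl`: > 50000 nM (a limit of the assay)

For the measured compounds named here, in a functional assay on A549 cells (Homo sapiens) for antiproliferative activity, read by MTT assay, with a stated time of 48 h (on this read-out lower numbers stand for stronger inhibition and higher numbers for weaker inhibition), compound 1 gives 32600 nM, the only actual number among the three compounds. Compound 2 reaches only the limit > 50000 nM in this assay. Compound 3 likewise stops at the limit > 50000 nM in this assay. The step of an at least 1.5-fold higher number from compound 1 to compound 2 (0.18 log units; that floor lies within the scatter) and the step of an at least 1.5-fold higher number from compound 1 to compound 3 (0.18 log units; that floor lies within the scatter) are therefore both read against (the limit of > 50000 nM in this assay, at which 2 of the 3 values shown sit), and the step that the two limits leave unreadable from compound 2 to compound 3 cannot be sized at all.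

Compound 4 `Cc1ccc(Cl)cc1-n1nncc1CN1C(=O)C2(C(C#N)=C(N)Oc3c2c2nc4ccccc4nc2c2ccccc32)c2ccccc21` differs from compound 1 by methyl in place of hydrogen on an aromatic carbon; cut one bond further out, the change reads 3-chlorophenyl to 5-chloro-2-methylphenyl. The step most closely resembling it is an at least 1.5-fold higher number from compound 1 to compound 3 (0.18 log units; that floor lies within the scatter), also methyl in place of hydrogen on an aromatic carbon, which moved the number upward at least to the limit. The step of an at least 1.5-fold higher number from compound 1 to compound 2 (0.18 log units; that floor lies within the scatter), a larger swap on the same aromatic nitrogen, went the same way.

Compound 4 is therefore expected to give about 45000 nM in this assay, within 22000 nM to 100000 nM. The expected step is a 1.4-fold higher number from compound 1 to compound 4 (0.14 log units; within the scatter), modestly weaker, with a fair chance that only a limit is reported.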

Compound 4, half-maximal inhibitory concentration: > 50000 nM
Compound 4 ended at the assay's limit (the forecaster's own chance of this, stated with the estimate: 50%); middle value at least 1.1-fold (0.04 log units) away from the limit.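

Placed on an aromatic carbon ortho to a large group and para to a chloro group, the methyl of the 5-chloro-2-methylphenyl group gives an at least 1.5-fold higher number from compound 1 to compound 4 (0.18 log units; that floor lies within the scatter) in this assay. For the compounds shown here, this shows that a methyl in this place, like the one in the 3-chloro-4-methylphenyl group of compound 3, yields no measured number, so two different placings of a methyl on the ring now end the same way. The true size of the step remains unknown, and the steps among compound 2, compound 3 and compound 4 cannot be read, leaving these three compounds without an order: the limit of > 50000 nM in this assay, at which 3 of the 4 values shown sit.

On these data alone, it remains open whether this carbon tolerates any group, for instance a fluoro, a methoxy or an amine in place of the methyl, and whether any of these would give a real number in this assay. Also open, as far as these compounds go, is whether a change on this ring can move activity clearly away from compound 1, at 32600 nM, in the stronger direction, for instance a carboxylic acid in place of the chloro group.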